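The source may report more compounds than this note shows. Statements on the series, on what has been measured and on what is new or still open speak of the compounds shown alone.

Measured in an in vitro ADME assay on microsomes from liver (Homo sapiens) for pharmacokinetics, read by LC-MS, with a stated time of 10 min, tested at 1 uM (on this read-out lower numbers stand for slow clearance and higher numbers for fast clearance), the compounds read:

- Compound 1 `Cc1cc(NC(=O)[C@H]2CN(C)C[C@@H]2c2ccc(/C=C/C(=O)Nc3ccccc3N)cc2)ccc1Cl` gives 15 mL/min/kg
- Compound 2 `CN1C[C@H](C(=O)Nc2ccc(F)cc2F)[C@@H](c2ccc(/C=C/C(=O)Nc3ccccc3N)cc2)C1` gives 12 mL/min/kg
- Compound 3 `CC(C)NC(=O)[C@H]1CN(C)C[C@@H]1c1ccc(/C=C/C(=O)Nc2ccccc2N)cc1` gives 8 mL/min/kg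

Compound 3 at 8 mL/min/kg lies within the scatter of both other compounds. Compound 4 `CN1C[C@H](C(=O)NC2CCCC2)[C@@H](c2ccc(/C=C/C(=O)Nc3ccccc3N)cc2)C1` has not yet been measured. Its difference from compound 3 is cyclopentyl in place of isopropyl on an amide-type nitrogen. For the measured compounds named here, no measured step makes this exact swap, but three replace the group on that nitrogen: a 1.3-fold lower number from compound 1 to compound 2 (0.10 log units; within the scatter) and a 1.9-fold lower number from compound 1 to compound 3 (0.27 log units; within the scatter) and a 1.5-fold lower number from compound 2 to compound 3 (0.18 log units; within the scatter) all stayed within the scatter. The estimated 1.3-fold higher number from compound 3 to compound 4 (0.10 log units; within the scatter) is therefore expected to stay within the scatter too. Expected for compound 4 is 10 mL/min/kg with 6 mL/min/kg to 17 mL/min/kg as the estimated range.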

Compound 4, clearance: 9 mL/min/kg
The estimate for compound 4 lay 1.1-fold (0.05 log units) above the measured number; low and high end bracket the measured number.
By their numbers in this assay, from the lowest: compounds 3, 4, 2 and 1 (each within the scatter of the next).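

Cyclopentyl brings a ring of carbon only to the amide-type nitrogen, and in this assay this saturated ring fits the same narrow range as the open-chain isopropyl and the two substituted phenyl groups. Thus a 1.1-fold higher number from compound 3 to compound 4 (0.05 log units; within the scatter) and a 1.3-fold lower number from compound 2 to compound 4 (0.12 log units; within the scatter) and a 1.7-fold lower number from compound 1 to compound 4 (0.22 log units; within the scatter) all stay within the scatter, so across these four compounds no group on this nitrogen stands apart. No supporting data explain this result.

Still open, from the compounds shown here alone, is whether an amine or a carboxylic acid on this nitrogen's substituent, or a longer chain, would give a step beyond the scatter.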